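From thiophen-2-yl to thiophen-3-yl on a shared core

This account rests on a few compounds, and the source may have more. Where it says the series, first, only, none or still open, it means among the compounds named here.

Compound 1 `NC(=O)c1ncn2c(=O)n(Cc3ccccc3)nnc12`: > 50000 nM
Compound 2 `NC(=O)c1ncn2c(=O)n(Cc3cccs3)nnc12`: > 50000 nM

In a functional assay on SNB-19 cells (Homo sapiens) for inhibition, read by MTT assay, with a stated time of 7 days (a lower number here means a stronger inhibitor of growth, a higher number a weaker inhibitor of growth), compound 1 gives > 50000 nM, which is a limit and not a number. In the same test compound 2 gives > 50000 nM, again a limit. Compound 2 therefore has no measured number, and the pair shares one ceiling: the limit of > 50000 nM in this assay, at which 2 of the 2 values shown sit.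

Compound 3 `NC(=O)c1ncn2c(=O)n(Cc3ccsc3)nnc12` keeps the shared core but carries thiophen-3-yl in place of thiophen-2-yl on a saturated chain carbon bound to an aromatic nitrogen. Among the measured compounds shown here, only one measured step bears on this change, a step that the two limits leave unreadable from compound 1 to compound 2, and it offers no size to carry over. No step beyond the scatter is therefore expected in this assay, and no direction can be given. The step expected from the estimate is a number no higher from compound 2 to compound 3 (the limit leaves the size open). Another limit is the most likely report. For compound 3 the expected value is 50000 nM, with an estimated range from 20000 nM to 100000 nM.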

Compound 3, concentration for 50% growth inhibition: > 50000 nM
Compound 3: no number, only a limit; the forecaster's own chance of this, stated with the estimate: 85%; the middle value sits exactly at the limit.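

No step can be read among compound 1, compound 2 and compound 3, since each result is a limit and not a number: the limit of > 50000 nM in this assay, at which 3 of the 3 values shown sit.

The compounds shown leave open whether phenyl, thiophen-2-yl and thiophen-3-yl differ at all in this assay.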